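The compounds below may be only part of what the source reports. "The series", "measured", "known", "first", "only" and "open" are said of these compounds alone.

Compound 1 `COc1cc(-c2cc(/C=C/C(=O)c3ccc(N)cc3)[nH]n2)cc(OC)c1OC` was tested in a functional assay on HT-29 cells (Homo sapiens) for inhibition, read by sulforhodamine B assay, with a stated time of 48 h (a lower number here means a stronger inhibitor of growth, a higher number a weaker inhibitor of growth), where compound 1 gives 4820 nM. Two close relatives were measured alongside it. Compound 2 `COc1ccc(-c2cc(/C=C/C(=O)c3ccc(OC)c(OC)c3)[nH]n2)cc1` gives 3450 nM in this assay, and compound 3 `COc1ccc(-c2cc(/C=C/C(=O)c3ccc(N)cc3)[nH]n2)cc1OC` gives 6910 nM in this assay. Compound 1 thus sits among numbers that differ from its own by no more than the usual scatter: the step of a 1.4-fold higher number from compound 1 to compound 3 (0.16 log units; within the scatter) is within the scatter, and compound 2 lies about as close on the other side.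

The next compound, compound 4 `COc1cc(-c2cc(/C=C/C(=O)c3ccc(F)c(F)c3)[nH]n2)cc(OC)c1OC`, differs from compound 1 at the ketone end: 3,4-difluorophenyl in place of 4-aminophenyl on a carbonyl carbon. Within the data shown here, no measured pair shows this change. Among the measured compounds shown here, the only measured step, a 1.4-fold higher number from compound 1 to compound 3 (0.16 log units; within the scatter), concerns a methoxy on the other aryl ring and is within the scatter; compound 2 differs from compound 1 at both ends, so its value speaks to no single change. With nothing bearing directly on the swap of 4-aminophenyl for 3,4-difluorophenyl, and all three measured numbers in this assay lying within the scatter of one another, no step beyond the scatter is expected for compound 4. Compound 4 is therefore estimated at 5000 nM in this assay, with a range from 2000 nM to 12500 nM, which means an expected step of a 1.0-fold higher number from compound 1 to compound 4 (0.02 log units; within the scatter).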

Compound 4, concentration for total growth inhibition: 6460 nM
For compound 4 the middle estimate is 1.3-fold (0.11 log units) below the measured one; the measured number falls inside the stated range.
By their numbers in this assay, from the lowest: compounds 2, 1, 4 and 3 (each within the scatter of the next).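

Among these compounds, the swap at the ketone end gives the first direct reading for this position: in this assay, 3,4-difluorophenyl in place of 4-aminophenyl on a carbonyl carbon gives a 1.3-fold higher number from compound 1 to compound 4 (0.13 log units; within the scatter). Among the compounds shown here, the group that leaves carries 1 hydrogen-bond donor and 1 hydrogen-bond acceptor and the group that enters carries 0 hydrogen-bond donors and 0 hydrogen-bond acceptors, yet on the core of compound 1 this exchange produces no step that can be told from the scatter. No measurement at hand offers an explanation for this result.

From the compounds shown here alone, this rests on a single pair, so it remains open whether the same exchange would also stay within the scatter on the core of compound 3. Going by these compounds, it is also open whether a quite different group on the carbonyl carbon, such as a 4-carboxyphenyl, a morpholine or a plain butyl chain, would move the number beyond the scatter, or whether this place tolerates changes more broadly than the two aryl groups compared here can show.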